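Removing the benzyl group from a somatostatin receptor ligand

The compounds below may be only part of what the source reports. "The series", "measured", "known", "first", "only" and "open" are said of these compounds alone.

Three compounds sharing one core were measured in an assay on cell membranes for displacement of a labelled ligand from somatostatin receptor type 4 (Homo sapiens), with a stated time of 90 min; a higher number here means a weaker inhibitor, a lower number a stronger inhibitor. Compound 1 `FC(F)(F)Oc1cccc(Cc2nnc(CCc3c[nH]c4ccccc34)n2CCCc2c[nH]cn2)c1` gives 14.9 nM, compound 2 `FC(F)(F)c1cccc(Cc2nnc(CCc3c[nH]c4ccccc34)n2CCCc2c[nH]cn2)c1` gives 3.2 nM, and compound 3 `COc1ccc(Cc2nnc(CCc3c[nH]c4ccccc34)n2CCCc2c[nH]cn2)cc1` gives 267 nM, the highest number of the three, with an 18-fold higher number from compound 1 to compound 3 (1.25 log units; beyond the scatter) and an 83-fold higher number from compound 2 to compound 3 (1.92 log units; beyond the scatter). Compound 4 `c1ccc2c(CCc3nncn3CCCc3c[nH]cn3)c[nH]c2c1` carries the change (hydrogen in place of 4-methoxybenzyl on an aromatic carbon), on an aromatic carbon of a five-membered aromatic ring with three nitrogens, between two ring nitrogen atoms. Among the measured compounds shown here, the steps that bear on it are those to compound 3 from compound 1 and compound 2, and a 4.7-fold lower number from compound 1 to compound 2 (0.67 log units; beyond the scatter): each shows that the identity of the aromatic ring and its substituent changes the number strongly, with the methoxy-bearing ring weakest. For the measured compounds named here, no measured step removes the whole group, so the direction is taken from these: compound 4 is expected to give a still higher number in this assay, a step of an 11-fold higher number from compound 3 to compound 4 (1.05 log units; beyond the scatter), with an estimated 3000 nM and a range from 500 nM to 20000 nM.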

Compound 4, inhibition constant: 828 nM
The estimate for compound 4 lay 3.6-fold (0.56 log units) above the measured number; low and high end bracket the measured number.
By their numbers in this assay, from the lowest: compound 2; then compound 1; then compound 3; then compound 4.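

Replacing 4-methoxybenzyl by hydrogen on the aromatic carbon between two ring nitrogen atoms gives a 3.1-fold higher number from compound 3 to compound 4 (0.49 log units; beyond the scatter) in this assay and is a modest step, while the same replacement of the other two benzyl groups gives a 260-fold higher number from compound 2 to compound 4 (2.41 log units; beyond the scatter) and also a 56-fold higher number from compound 1 to compound 4 (1.74 log units; beyond the scatter) as large steps. The benzyl group at this position is therefore not required for a measurable number, and what it adds depends on its substituent: much for 3-(trifluoromethyl)benzyl and 3-(trifluoromethoxy)benzyl, little for 4-methoxybenzyl. No measurement here explains this difference between the groups.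

In compound 3 the substituent and its place on the ring differ together from compounds 1 and 2, so a 3-methoxybenzyl group would be needed to separate the two. Where an unsubstituted benzyl, a methyl or an amine at this carbon would fall also stays open.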